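A few compounds are considered here, and "the series" means these few. Any claim that something is new, unique, unknown or untested is made for them only; others in the source may bear on it.

Compound 1 `COc1cc(C(=O)N(C)C)ccc1Nc1nc(O[C@H]2CC[C@](C)(O)CC2)c2cc[nH]c2n1` and compound 2 `COc1cc(N2CCC(C)(O)CC2)ccc1Nc1nc(O[C@H]2CCOC(C)(C)C2)c2cc[nH]c2n1` share a common core. In a functional assay on CAL-51 cells (Homo sapiens) for antiproliferative activity, read by luminescence and CellTiter-Glo, with a stated time of 3 days (on this read-out higher numbers stand for weaker inhibition and lower numbers for stronger inhibition), compound 1 gives 69 nM and compound 2 gives 71 nM; these two numbers sit within the scatter of each other, so neither can be called the more potent. Compound 3 `COc1cc(C(=O)N(C)C)ccc1Nc1nc(OC2CCOCC2)c2cc[nH]c2n1` has not yet been measured. It differs from compound 1 by oxan-4-yl in place of 4-hydroxy-4-methylcyclohexyl on an oxygen on an aromatic ring. For the measured compounds named here, no measured pair shows this change, so its size is unknown. The expected step of a 1.9-fold higher number from compound 1 to compound 3 (0.28 log units; within the scatter) in this assay is a small weakening, possibly none beyond the scatter. Compound 3 is estimated at 130 nM, with a range from 50 nM to 350 nM.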

Compound 3, half-maximal inhibitory concentration: 198 nM
Compound 3: the middle estimate sits 1.5-fold (0.18 log units) below what was measured, within the range that was stated.
By their numbers in this assay, from the lowest: compounds 1 and 2 (each within the scatter of the next); then compound 3.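

In this assay, the change on this oxygen from 4-hydroxy-4-methylcyclohexyl to oxan-4-yl gives a 2.9-fold higher number from compound 1 to compound 3 (0.46 log units; beyond the scatter), a modest weakening, so this position does respond to the group it carries. The group leaving has a hydrogen-bond donor and the group entering has none, but the ring atoms and the size change in the same step, so this one pair cannot separate these differences. No measurement at hand explains the step. On these data alone, it remains open how a plain cyclohexyl or a piperidin-4-yl on this oxygen would compare with compound 1 and compound 3.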